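Nitro to Methoxycarbonyl Swap on the Fused Phenol Core

The source may report more compounds than this note shows. Statements on the series, on what has been measured and on what is new or still open speak of the compounds shown alone.

Compound 2 `CS(=O)(=O)N1CC(CCl)c2cc([N+](=O)[O-])c(O)cc21` gives 8.85 ug/mL in a functional assay on KB cells (Homo sapiens), read by crystal violet staining (a higher number here means a weaker inhibitor, a lower number a stronger inhibitor), the highest of the three numbers in hand. Compound 1 `CS(=O)(=O)OCC1CN(S(C)(=O)=O)c2cc(OCc3ccccc3)ccc21` gives 4.39 ug/mL in this assay, within the scatter of compound 2. Compound 3 `CS(=O)(=O)N1CC(CCl)c2cc(C=O)c(OCc3ccccc3)cc21` gives 3.24 ug/mL in this assay, a gap from compound 2 that lies beyond the scatter. No two of these compounds differ in only one place, so no measured step guides the next change. Compound 4 `COC(=O)c1cc2c(cc1O)N(S(C)(=O)=O)CC2CCl` carries methoxycarbonyl in place of nitro on an aromatic carbon, ortho to a hydroxy group, meta to a fused ring and para to a fused ring. Among the measured compounds shown here, with no measured step for such a swap, the step of a 1.3-fold lower number from compound 2 to compound 4 (0.10 log units; within the scatter) is expected to be small, if anything toward a lower number, and probably within the scatter. Compound 4 is estimated at 7 ug/mL, within 2.5 ug/mL to 20 ug/mL.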

Compound 4, half-maximal inhibitory concentration: 8.38 ug/mL
The estimate for compound 4 lay 1.2-fold (0.08 log units) below the measured number; the measured number falls inside the stated range.
By their numbers in this assay, from the lowest: compounds 3, 1, 4 and 2 (each within the scatter of the next, the first and the last beyond it).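

In this assay, among the compounds shown here, the first single-place step is a 1.1-fold lower number from compound 2 to compound 4 (0.02 log units; within the scatter). For the compounds shown here, at this aromatic carbon, ortho to a hydroxy group, the read-out therefore does not separate methoxycarbonyl from nitro, although the earlier compounds gave no measure of any change here. No measurement at hand bears on the reason for this result.

As far as these compounds go, whether an amine or a carboxylic acid on this carbon would also stay within the scatter remains open. So does whether a longer ester chain, such as ethoxycarbonyl, would give a number apart from compound 4 8.38 ug/mL.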